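Trifluoromethyl for Phenoxy in a Phenoxybutanoic Acid Series

The compounds below may be only part of what the source reports. "The series", "measured", "known", "first", "only" and "open" are said of these compounds alone.

Compound 1 `O=C(O)CCCOc1ccc(-c2noc3ccccc23)c(Cl)c1Cl`: > 9950 nM
Compound 2 `O=C(O)CCCOc1ccc(-c2ccccc2Oc2ccccc2)cc1`: > 9950 nM

Of the compounds shown here, two have been measured in a functional assay on isolated protein for agonist activity at Free fatty acid receptor 1 (Homo sapiens), read by HTRF and inositol phosphate accumulation, with a stated time of 60 min; on this read-out higher numbers stand for an effect only at larger amounts of compound and lower numbers for an effect already at smaller amounts. In this assay compound 1 returns only a limit, > 9950 nM. In this assay compound 2 likewise returns only a limit, > 9950 nM. Compound 2 therefore stands at the same limit as compound 1, and the two values cannot be placed in any order against each other (the limit of > 9950 nM in this assay, at which 2 of the 2 values shown sit).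

The next compound, compound 3 `O=C(O)CCCOc1ccc(-c2ccccc2C(F)(F)F)cc1`, differs from compound 2 in one place: trifluoromethyl in place of phenoxy on an aromatic carbon. Going by the values given here, no measured step between compounds of this set exists to guide the size or direction of this change, and compound 1 and compound 2 both sit at the limit, so the numbers so far say nothing about where a number for compound 3 would fall once one is obtained.

The working expectation is that compound 3 stays close to where compound 2 sits, with the step from compound 2 to compound 3 expected as an at least 1.4-fold lower number from compound 2 to compound 3 (0.15 log units; that floor lies within the scatter). Compound 3 is accordingly estimated at 7000 nM in this assay, within a range of 1500 nM to 30000 nM.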

Compound 3, half-maximal effective concentration: > 9950 nM
Compound 3: no number, only a limit (the forecaster's own chance of this, stated with the estimate: 60%); middle value at least 1.4-fold (0.15 log units) from the limit.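

In this assay compound 3 returns only a limit, > 9950 nM. Compound 2 also stands at a limit, so the step between compound 2 and compound 3 cannot be read: the limit of > 9950 nM in this assay, at which 3 of the 3 values shown sit.

The compounds shown leave open whether trifluoromethyl in place of phenoxy changes the result in this assay, and what number any of the three compounds would give.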